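Hydrazone aryl variation on the chloropyrimidine series

A few compounds are considered here, and "the series" means these few. Any claim that something is new, unique, unknown or untested is made for them only; others in the source may bear on it.

Two compounds of this series have a number in an ADME assay on HT-29 cells (Homo sapiens) for inhibition, read by MTT assay, with a stated time of 72 h; a higher number here means a weaker inhibitor, a lower number a stronger inhibitor. Compound 1 `CN(C)C/C=C/C(=O)Nc1cccc(Nc2nc(N/N=C/c3ccccc3F)ncc2Cl)c1` gives 3660 nM in this assay. Compound 2 `C/C(=N\Nc1ncc(Cl)c(Nc2cccc(NC(=O)/C=C/CN(C)C)c2)n1)c1ccc(F)cc1F` gives 3460 nM in this assay. The one step between them, a 1.1-fold lower number from compound 1 to compound 2 (0.02 log units; within the scatter), lies within the scatter, so compound 2 and compound 1 stand together and neither can be told apart from the other on the numbers shown.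

Compound 3 `COc1ccc(/C(C)=N/Nc2ncc(Cl)c(Nc3cccc(NC(=O)/C=C/CN(C)C)c3)n2)cc1` has not yet been measured in this assay. It differs from compound 2 by 4-methoxyphenyl in place of 2,4-difluorophenyl on a carbon with a double bond to nitrogen. This is the same part of the molecule that was changed in the step from compound 1 to compound 2, where exchanging one aryl group for another on the hydrazone left the number in this assay within the scatter. For the measured compounds named here, with only that one step to go on, the exchange of 2,4-difluorophenyl for 4-methoxyphenyl is expected to give no step beyond the scatter, as a 1.0-fold higher number from compound 2 to compound 3 (0.00 log units; within the scatter). Compound 3 is therefore expected to give about 3500 nM in this assay, with a range from 1500 nM to 8000 nM.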

Compound 3, half-maximal inhibitory concentration: 6830 nM
Compound 3: the middle estimate sits 2.0-fold (0.29 log units) below what was measured, and the stated range covers the measured number.
By their numbers in this assay, from the lowest: compounds 2, 1 and 3 (each within the scatter of the next).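

In this assay, the exchange of 2,4-difluorophenyl for 4-methoxyphenyl on the carbon with a double bond to nitrogen gives a 2.0-fold higher number from compound 2 to compound 3 (0.30 log units; within the scatter). This extends the earlier reading at this position to an aryl group without fluorine, with oxygen entering and the hydrogen-bond acceptor count of the group going from 0 to 1, and the step still does not leave the scatter. The larger exchange on the nitrogen on an aromatic ring gives a 1.9-fold higher number from compound 1 to compound 3 (0.27 log units; within the scatter), so the three compounds cannot be told apart on these numbers, and no measurement shown here offers an account of them.

From the compounds shown here alone, all three groups carry a six-membered aromatic ring of carbon only, so it remains open whether cyclohexyl, a pyridine ring or a phenyl ring bearing a carboxylic acid at this carbon would give a step beyond the scatter. Compound 1 differs from compound 2 and compound 3 in both the aryl group and the methyl on this carbon, so the compounds shown do not separate the contribution of the methyl from that of the aryl group.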